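The source may report more compounds than this note shows. Statements on the series, on what has been measured and on what is new or still open speak of the compounds shown alone.

Compound 1 `COc1cc(C(c2ccc(O)c(OC)c2)[C@@H](C)[C@@H](C)CF)ccc1O` gives 38000 nM in a functional assay on HL-60 cells (Homo sapiens) for cytotoxicity, read by WST assay, with a stated time of 48 h (a higher number here means a weaker inhibitor, a lower number a stronger inhibitor), the highest of the three numbers. Compound 2 `COc1cc(C(c2ccc(O)c(OC)c2)[C@H](CF)C(C)C)ccc1O` gives 19000 nM, and a 2.0-fold lower number from compound 1 to compound 2 (0.30 log units; within the scatter). Compound 3 `COc1cc(C(c2ccc(O)c(OC)c2)[C@H](CC(C)C)C(C)C)ccc1O` gives 9600 nM, and a 4.0-fold lower number from compound 1 to compound 3 (0.60 log units; beyond the scatter); between the other two, a 2.0-fold lower number from compound 2 to compound 3 (0.30 log units; within the scatter). Compound 4 `CCCCC[C@H](C(C)C)C(c1ccc(O)c(OC)c1)c1ccc(O)c(OC)c1` has not yet been measured in this assay. Its change from compound 1 is 1-isopropylhexyl in place of 2-(fluoromethyl)-1-methylpropyl on a saturated chain carbon bound to two aromatic carbons. Among the compounds with values here, the steps that bear on it are the exchange of 2-(fluoromethyl)-1-methylpropyl for 1-isopropyl-3-methylbutyl in compound 3, a modest step beyond the scatter, and the exchange of fluoro for isopropyl in compound 3, which stayed within the scatter. Compound 4 is therefore expected to show a modest step downward, a 4.0-fold lower number from compound 1 to compound 4 (0.60 log units; beyond the scatter). The estimate for compound 4 is 9500 nM, with a range from 4000 nM to 25000 nM.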

Compound 4, half-maximal inhibitory concentration: 9600 nM
Compound 4: the middle estimate sits 1.0-fold (0.00 log units) below what was measured; low and high end bracket the measured number.
By their numbers in this assay, from the lowest: compounds 3, 4, 2 and 1 (each within the scatter of the next, the first and the last beyond it).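

Within this assay, a 4.0-fold lower number from compound 1 to compound 4 (0.60 log units; beyond the scatter) comes with 1-isopropylhexyl in place of 2-(fluoromethyl)-1-methylpropyl, so a group with no fluorine reaches this level by a second chain. Three bonds along the chain from two aromatic carbons, butyl in place of isopropyl gives no change at the digits printed from compound 3 to compound 4 (within the scatter) and butyl in place of fluoro gives a 2.0-fold lower number from compound 2 to compound 4 (0.30 log units; within the scatter), so these compounds do not separate butyl from isopropyl or fluoro there. No evidence accounts for these steps. From the compounds shown here alone, whether an amine, a carboxylic acid or a longer chain at that place would shift the number remains open.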